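Swapping the Ether Group on a Chloro-Bearing Analogue

This account rests on a few compounds, and the source may have more. Where it says the series, first, only, none or still open, it means among the compounds named here.

Measured compounds:
compound 1, `CC(C)CCn1ccc(-c2ccc(OCC3CC3)cc2)c(C#N)c1=O`: 290 nM
compound 2, `CC(C)CCn1ccc(-c2ccc(OCC3CC3)c(Cl)c2)c(C#N)c1=O`: 110 nM

In a functional assay on CHO cells for positive allosteric modulation of metabotropic glutamate receptor 2 (Homo sapiens), read by scintillation counting and GTPgammaS binding, with a stated time of 30 min (on this read-out higher numbers stand for an effect only at larger amounts of compound and lower numbers for an effect already at smaller amounts), compound 1 gives 290 nM and compound 2 gives 110 nM. Among the compounds with values here, compound 2 has the lowest of the two numbers; the only step between them is a 2.6-fold lower number from compound 1 to compound 2 (0.42 log units; beyond the scatter), which came from a chloro in place of hydrogen on an aromatic carbon.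

Compound 3, `CC(C)CCn1ccc(-c2ccc(OC3CCOCC3)c(Cl)c2)c(C#N)c1=O`, keeps that chloro and the rest of compound 2 but differs at the ether: oxan-4-yl in place of cyclopropylmethyl on an oxygen on an aromatic ring. Within the data shown here, no measured pair changes this ether group, so the measured step says nothing directly about the change from compound 2 to compound 3. With no guidance, the expected step of a 1.4-fold higher number from compound 2 to compound 3 (0.13 log units; within the scatter) is a small one, not clearly beyond the scatter in either direction. Compound 3 is therefore estimated at 150 nM in this assay, within a range from 40 nM to 600 nM.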

Compound 3, half-maximal effective concentration: 186 nM
Estimate against measurement, compound 3: 1.2-fold (0.09 log units) below; measured number inside the range.
By their numbers in this assay, from the lowest: compounds 2, 3 and 1 (each within the scatter of the next, the first and the last beyond it).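

At this oxygen on an aromatic ring, replacing cyclopropylmethyl with oxan-4-yl gives a 1.7-fold higher number from compound 2 to compound 3 (0.23 log units; within the scatter) in this assay. The change raises the heavy-atom count from 4 to 6, replaces a three-membered carbon ring with a six-membered ring containing oxygen, and adds a hydrogen-bond acceptor, yet the two values cannot be told apart. This position therefore accepts at least one substantial change of ether group without a step beyond the scatter, something the chloro step could not show. No supporting data bear on the reason for this result.

Only this one swap at the oxygen is shown, so the outcome with a simple methyl group or an amine such as piperidin-4-yl remains open. On these data alone, whether the same swap would read alike without the chloro also remains unknown.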